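The source may hold more compounds than are shown below. What is called first, only, known or untested is meant among the compounds shown, and "the series" means these compounds.

In an ADME assay on HEL cells (Homo sapiens), read by cell counting, with a stated time of 3 days (on this read-out lower numbers stand for higher toxicity in this test and higher numbers for lower toxicity in this test), compound 1 `CCCCCCc1ccc(C#CC#Cc2cn([C@H]3C[C@H](O)[C@@H](CO)O3)c(=O)[nH]c2=O)cc1` gives 35000 nM, the higher of the two numbers in the series, while compound 3 `O=c1[nH]c(=O)n([C@H]2C[C@H](O)[C@@H](CO)O2)cc1C#CC#Cc1ccccn1` gives 1500 nM. Compound 2 `COc1cc(C#CC#Cc2cn([C@H]3C[C@H](O)[C@@H](CO)O3)c(=O)[nH]c2=O)cc(OC)c1` reads > 100000 nM, which is a limit of the assay. Compound 4 `O=c1[nH]c(=O)n([C@H]2C[C@H](O)[C@@H](CO)O2)cc1C#CC#Cc1ccc(OC(F)(F)F)cc1` differs from compound 1 by trifluoromethoxy in place of hexyl on an aromatic carbon, para to a large group. Among the measured compounds shown here, the only measured step, an at least 66-fold lower number from compound 2 to compound 3 (1.82 log units; beyond the scatter), is large, but it replaces the whole group on the triple-bonded carbon, so it bears only loosely on this change. For the measured compounds named here, compound 4 keeps the aromatic ring of carbon only found in compound 1, so no step of that size is expected in this assay. The estimated step is a 1.4-fold higher number from compound 1 to compound 4 (0.15 log units; within the scatter), with no change expected beyond the scatter. For compound 4 the expected value is 50000 nM, with an estimated range of 12000 nM to 100000 nM.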

Compound 4, half-maximal cytotoxic concentration: 55000 nM
Compound 4: middle estimate off by 1.1-fold (0.04 log units), on the low side; the measured number falls inside the stated range.
By their numbers in this assay, from the lowest: compound 3; then compounds 1 and 4 (each within the scatter of the next). At a limit, above all of these: compound 2.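

At the aromatic carbon para to a large group, trifluoromethoxy in place of hexyl gives a 1.6-fold higher number from compound 1 to compound 4 (0.20 log units; within the scatter) in this assay. This is the first step shown at this position, and this assay does not separate the two groups here, although they differ in their atoms.

As far as these compounds go, whether an amine or a carboxylic acid at this position would move the number beyond the scatter stays open. A rise from any such group could be read only up to a ceiling: the limit of > 100000 nM in this assay, at which 1 of the 4 values shown sits.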